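Bromo in place of hydrogen on the shared core: notes

The compounds below may be only part of what the source reports. "The series", "measured", "known", "first", "only" and "open" are said of these compounds alone.

In a functional assay on KB cells (Homo sapiens) for inhibition, with a stated time of 72 h (on this read-out higher numbers stand for weaker inhibition and lower numbers for stronger inhibition), the measured compounds stand as follows:
compound 1 `CC(=O)Oc1cc2oc(-c3ccccc3)cc(=O)c2c(O)c1OC(C)=O` gives 12700 nM;
compound 2 `CC(=O)Oc1cc2oc(-c3ccccc3)cc(=O)c2c(OC(C)=O)c1OC(C)=O` gives 14500 nM;
compound 3 `CC(=O)Oc1cc2oc(-c3ccccc3)cc(=O)c2c(OCc2ccccc2)c1OC(C)=O` gives 11300 nM.

All three numbers lie within the scatter of one another. The steps away from compound 1 are a 1.1-fold higher number from compound 1 to compound 2 (0.06 log units; within the scatter) and a 1.1-fold lower number from compound 1 to compound 3 (0.05 log units; within the scatter), and between the other two a 1.3-fold lower number from compound 2 to compound 3 (0.11 log units; within the scatter). Compound 4 `CC(=O)Oc1c(OC(C)=O)c(O)c2c(=O)cc(-c3ccccc3)oc2c1Br` differs from compound 1 by bromo in place of hydrogen on an aromatic carbon. For the measured compounds named here, every measured step exchanges a group on an oxygen; none puts a bromo on an aromatic carbon, so no measured step bears directly on this change, and all three stayed within the scatter. On that basis no step beyond the scatter is expected in this assay, a 1.1-fold lower number from compound 1 to compound 4 (0.02 log units; within the scatter). Compound 4 is therefore estimated at 12000 nM, in the range 4000 nM to 36000 nM.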

Compound 4, half-maximal inhibitory concentration: 12400 nM
Compound 4: middle estimate off by 1.0-fold (0.01 log units), on the low side; the range from low to high includes it.
By their numbers in this assay, from the lowest: compounds 3, 4, 1 and 2 (each within the scatter of the next).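

In this assay, bromo in place of hydrogen on the aromatic carbon para to a hydroxy group gives a 1.0-fold lower number from compound 1 to compound 4 (0.01 log units; within the scatter) and so extends the flat picture from exchanges on oxygen to a change on the ring carbon itself. This position, ortho to an acetoxy group, therefore takes a single bromine atom without a step beyond the scatter. No supporting measurement bears on why this is so.

Open, going by these compounds, is whether an amine or a carboxylic acid at this carbon would also stay within the scatter. Also open, on these data alone, is whether bromo would behave alike with a benzyl or acetyl group on the hydroxy oxygen.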